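Aryl sulfone variation on a shared quinoline-type core

The source may report more compounds than this note shows. Statements on the series, on what has been measured and on what is new or still open speak of the compounds shown alone.

Measured so far:
compound 1 `O=S(=O)(c1cc(Cl)cc(Cl)c1)c1cnc2cc(F)ccc2c1-c1cccc(F)c1` gives 35 nM
compound 2 `O=S(=O)(c1cc(Cl)cc(Cl)c1)c1cnc2c(F)cccc2c1-c1ccc(F)cc1` gives 25 nM

Both numbers come from a functional assay on cells for negative allosteric modulation of metabotropic glutamate receptor 5 (Homo sapiens), read by fluorescence and calcium flux, with a stated time of 20 min; a higher number here means a weaker inhibitor, a lower number a stronger inhibitor. Compound 2 and compound 1 differ by less than the usual scatter, so neither stands apart from the other; nothing beyond the sulfonyl aryl group held in common can be read from the pair.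

Compound 3 `O=S(=O)(c1cccc(F)c1)c1cnc2c(F)cccc2c1-c1ccc(F)cc1` has not been measured. Relative to compound 2 the change is 3-fluorophenyl in place of 3,5-dichlorophenyl on a sulfonyl sulfur. Among the compounds with values here, no measured pair shows this change, so its size is unknown here. The expectation is a moderate loss, a step of about a 3.2-fold higher number from compound 2 to compound 3 (0.51 log units; beyond the scatter) toward weaker inhibition in this assay. Compound 3 is therefore estimated at 80 nM, with a plausible range from 25 nM to 300 nM.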

Compound 3, half-maximal inhibitory concentration: 69 nM
Estimate against measurement, compound 3: 1.2-fold (0.06 log units) above; low and high end bracket the measured number.
By their numbers in this assay, from the lowest: compounds 2, 1 and 3 (each within the scatter of the next, the first and the last beyond it).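

In this assay, within the data shown here, the sulfonyl aryl group now has a measured effect: 3-fluorophenyl in place of 3,5-dichlorophenyl on a sulfonyl sulfur gives a 2.8-fold higher number from compound 2 to compound 3 (0.44 log units; beyond the scatter) toward weaker inhibition, the first one-place change. The position therefore responds to this exchange, but the step is modest and compound 3 remains an inhibitor, so this pair does not show the 3,5-dichlorophenyl group to be essential. Nothing available explains the size of the step.

Both chlorines leave and a fluorine enters in the same change, so the pair cannot separate their contributions; 3-chlorophenyl or unsubstituted phenyl on the sulfonyl sulfur would address that. Going by these compounds, how a pyridine ring or a saturated amine such as morpholine would behave at this place also remains open.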